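The source may report more compounds than this note shows. Statements on the series, on what has been measured and on what is new or still open speak of the compounds shown alone.

Measured compounds:
compound 1 `C=CC(=O)Nc1cc(Nc2ncc(Cl)c(Nc3ccccc3S(=O)(=O)C(C)C)n2)c(OC)cc1N1CCCCC1`, in a functional assay on NCI-H1975 cells (Homo sapiens) for inhibition, read by CellTiter-Glo, with a stated time of 72 h (a higher number here means a weaker inhibitor of growth, a lower number a stronger inhibitor of growth), compound 1 gives 240 nM;
compound 2 `C=CC(=O)Nc1cc(Nc2ncc(C)c(Nc3ccccc3S(=O)(=O)C(C)C)n2)c(OC)cc1N1CCC(N2CCN(C)CC2)CC1`, in this assay compound 2 gives 27 nM;
compound 3 `C=CC(=O)Nc1cc(Nc2ncc(Cl)c(Nc3ccc(F)c(Cl)c3)n2)c(OC)cc1N1CCN(C)CC1`, in this assay compound 3 gives 100 nM.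

Among these three numbers compound 3 stands second highest. Its nearest neighbour is compound 1, whose higher number lies beyond the scatter, and its furthest is compound 2, whose lower number also lies beyond the scatter. Compound 4 `C=CC(=O)Nc1cc(Nc2ncc(Cl)c(NC3CC3)n2)c(OC)cc1N1CCN(C)CC1` differs from compound 3 in one place: cyclopropyl in place of 3-chloro-4-fluorophenyl on a nitrogen on an aromatic ring. Going by the values given here, no measured pair shows this change, so its size must be guessed. Since every measured compound carries a six-membered aromatic ring on that nitrogen, the shift to a small saturated ring is expected to cost potency in this assay, a step of a 6.0-fold higher number from compound 3 to compound 4 (0.78 log units; beyond the scatter) beyond the scatter. Compound 4 is therefore estimated at 600 nM, with a range from 150 nM to 3000 nM.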

Compound 4, concentration for 50% growth inhibition: > 10000 nM
Compound 4 gave a limit, no number (the forecaster's own chance of this, stated with the estimate: 10%); at least 16-fold (1.22 log units) between middle value and limit.
By their numbers in this assay, from the lowest: compound 2; then compound 3; then compound 1. At a limit, above all of these: compound 4.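

On the nitrogen on an aromatic ring, cyclopropyl in place of 3-chloro-4-fluorophenyl gives an at least 100-fold higher number from compound 3 to compound 4 (2.00 log units; beyond the scatter) as the first step read at this place. In this assay compound 4 gives > 10000 nM as a limit of the assay, not a number. This place therefore does not tolerate every group, while the full size of the step stays unfixed: the limit of > 10000 nM in this assay, at which 1 of the 4 values shown sits.

The compounds shown leave open whether an unsubstituted phenyl, a cyclohexyl or a longer chain such as n-butyl on that nitrogen would restore growth inhibition.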